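The source may hold more compounds than are shown below. What is called first, only, known or untested is meant among the compounds shown, and "the series" means these compounds.

Three compounds have been measured in a functional assay on HGC-27 cells (Homo sapiens) for cytotoxicity, read by MTT assay, with a stated time of 72 h; a lower number here means a stronger inhibitor, a higher number a weaker inhibitor:
compound 1 `CCCCCCCCCCCCNc1nc(SCc2ccc(C(F)(F)F)cc2)nc2ccccc12` gives 38700 nM.
compound 2 `CCCCCCCCCCCCCCNc1nc(SCc2ccc(C(F)(F)F)cc2)nc2ccccc12` gives only a limit of the assay, > 50000 nM.
compound 3 `FC(F)(F)c1ccc(CSc2nc(Nc3cccc(Cl)c3)c3ccccc3n2)cc1` gives 19900 nM.

Compound 3 holds the lowest of the two numbers, and its nearest neighbour is compound 1, a gap within the usual scatter. The third value is the limit of compound 2. Among the measured compounds shown here, the only measured step, an at least 1.2-fold higher number from compound 1 to compound 2 (0.11 log units; that floor lies within the scatter), lengthens a chain and leaves the group on the aromatic nitrogen untouched, so it does not bear on the change to compound 4 `COc1ccc(Nc2nc(SCc3ccc(C(F)(F)F)cc3)nc3ccccc23)c(OC)c1`, which is 2,4-dimethoxyphenyl in place of 3-chlorophenyl on a nitrogen on an aromatic ring. For the measured compounds named here, with no measured step speaking to this exchange, no step beyond the scatter is expected in either direction in this assay. Compound 4 is therefore estimated near 22000 nM, between 7000 nM and 60000 nM, an expected step of a 1.1-fold higher number from compound 3 to compound 4 (0.04 log units; within the scatter).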

Compound 4, half-maximal inhibitory concentration: > 50000 nM
Compound 4: a limit, no number; the forecaster's own chance of this, stated with the estimate: 25%; middle value at least 2.2-fold (0.35 log units) away from the limit.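

In this assay, the group on this nitrogen proves able to move the result: 2,4-dimethoxyphenyl in place of 3-chlorophenyl brings an at least 2.5-fold higher number from compound 3 to compound 4 (0.40 log units; beyond the scatter). The earlier chain step had shown nothing beyond the scatter, and it did not touch this aryl group. The result for compound 4 is a limit, not a number, which makes this step a floor whose full size stays unknown: the limit of > 50000 nM in this assay, at which 2 of the 4 values shown sit.

From the compounds shown here alone, whether both methoxy groups are needed for this step remains open. A single methoxy group on the phenyl ring, or a plain phenyl, would help to separate the two.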